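Taking the methyl group off compound 3

This account rests on a few compounds, and the source may have more. Where it says the series, first, only, none or still open, it means among the compounds named here.

Three compounds share one core and differ only in the methylphenyl group on an aromatic nitrogen. In a functional assay on HCT-116 cells (Homo sapiens) for inhibition, read by MTT assay, with a stated time of 72 h (on this read-out higher numbers stand for weaker inhibition and lower numbers for stronger inhibition), compound 1 `COc1cc2c(Oc3ccc(NC(=O)c4nn(-c5ccc(C)cc5)cc(C)c4=O)cc3)ccnc2cc1OCCCCCCC(=O)NO`, with 4-methylphenyl, gives 400 nM. Compound 2 `COc1cc2c(Oc3ccc(NC(=O)c4nn(-c5cccc(C)c5)cc(C)c4=O)cc3)ccnc2cc1OCCCCCCC(=O)NO`, with 3-methylphenyl, gives 370 nM. Compound 3 `COc1cc2c(Oc3ccc(NC(=O)c4nn(-c5ccccc5C)cc(C)c4=O)cc3)ccnc2cc1OCCCCCCC(=O)NO`, with 2-methylphenyl, gives 660 nM. Compound 3 stands within the scatter of both others, as seen in a 1.7-fold higher number from compound 1 to compound 3 (0.22 log units; within the scatter) and in a 1.8-fold higher number from compound 2 to compound 3 (0.25 log units; within the scatter).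

Compound 4 `COc1cc2c(Oc3ccc(NC(=O)c4nn(-c5ccccc5)cc(C)c4=O)cc3)ccnc2cc1OCCCCCCC(=O)NO` has the methyl group removed: hydrogen in place of methyl on an aromatic carbon. This puts hydrogen in place of methyl on an aromatic carbon, so 2-methylphenyl becomes phenyl. For the measured compounds named here, no measured step shows this exact change. The closest evidence is the moving of the methyl group, and those steps are all small, including a 1.1-fold lower number from compound 1 to compound 2 (0.03 log units; within the scatter). A large step in this assay is therefore not expected, and the value should stay near those of the three measured compounds. The expected step is a 1.5-fold lower number from compound 3 to compound 4 (0.17 log units; within the scatter), which would lie within the scatter. For compound 4 the estimated value is 450 nM, with an expected range of 230 nM to 850 nM.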

Compound 4, half-maximal inhibitory concentration: 150 nM
Compound 4: middle estimate off by 3.0-fold (0.48 log units), on the high side; the measured number lies below the stated range.
By their numbers in this assay, from the lowest: compound 4; then compounds 2, 1 and 3 (each within the scatter of the next).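

Removing the methyl group altogether does what moving it around the ring did not: in this assay the change gives a 4.4-fold lower number from compound 3 to compound 4 (0.64 log units; beyond the scatter), and compound 4 also separates from the other two methylphenyl compounds, with a 2.5-fold lower number from compound 2 to compound 4 (0.39 log units; beyond the scatter) and a 2.7-fold lower number from compound 1 to compound 4 (0.43 log units; beyond the scatter). Across these four compounds, then, whether a methyl group is present on this ring counts for more than where it sits, since all three methylphenyl compounds give higher numbers than the plain phenyl of compound 4. Nothing available here explains why the loss of this one carbon has such an effect.

On these data alone, it remains open whether a different group on this ring, such as a fluorine atom, a methoxy group or an amine, would behave like hydrogen or like methyl. As far as these compounds go, it is also open whether the same step would appear in any read-out other than this cell assay.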